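This account rests on a few compounds, and the source may have more. Where it says the series, first, only, none or still open, it means among the compounds named here.

Among the measured compounds shown here, compound 2 `Nc1cc(-c2nc(C(c3ccc(F)cc3)c3ccc(F)cc3)sc2CC(=O)O)cc(F)n1` gives 220 nM in an in vitro assay on HEK385-7 cells for displacement of a labelled ligand from prostaglandin D2 receptor 2 (Homo sapiens) (a higher number here means a weaker inhibitor, a lower number a stronger inhibitor), the highest of the two numbers measured so far; its nearest neighbour, compound 1 `O=C(O)Cc1sc(C(c2ccc(F)cc2)c2ccc(F)cc2)nc1-c1ccncc1`, gives 5.3 nM. For the measured compounds named here, the one measured step between them, a 42-fold higher number from compound 1 to compound 2 (1.62 log units; beyond the scatter), comes from replacing pyridin-4-yl with 2-amino-6-fluoropyridin-4-yl, so a change to the substitution of this ring has already moved this assay by a large amount. Compound 3 `O=C(O)Cc1sc(C(c2ccc(F)cc2)c2ccc(F)cc2)nc1-c1ccnc(N2CCCC2)c1` takes the same ring in another direction: 2-(pyrrolidin-1-yl)pyridin-4-yl in place of 2-amino-6-fluoropyridin-4-yl on an aromatic carbon. That step bears most directly on the change from compound 1 to compound 2, but it removes the ring fluorine and exchanges the amino group for a pyrrolidinyl group at once, so neither its direction nor its size can be read off that single measured step. Compound 3 is therefore expected to land between its two neighbours, a step of a 4.4-fold lower number from compound 2 to compound 3 (0.64 log units; beyond the scatter), with an estimate of 50 nM and a range from 10 nM to 250 nM.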

Compound 3, half-maximal inhibitory concentration: 230 nM
Beside the measured number, compound 3's estimate is 4.6-fold (0.66 log units) below it; low and high end bracket the measured number.
By their numbers in this assay, from the lowest: compound 1; then compounds 2 and 3 (each within the scatter of the next).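

In this assay the exchange of the two substituted rings gives a 1.0-fold higher number from compound 2 to compound 3 (0.02 log units; within the scatter), so 2-(pyrrolidin-1-yl)pyridin-4-yl and 2-amino-6-fluoropyridin-4-yl cannot be told apart at this position, despite their different substituents. The direct comparison with the unsubstituted ring gives a 43-fold higher number from compound 1 to compound 3 (1.64 log units; beyond the scatter), a large step like a 42-fold higher number from compound 1 to compound 2 (1.62 log units; beyond the scatter), so among the three compounds shown, both substituted pyridinyl rings carry a much higher number than pyridin-4-yl, and no compound goes against this. Nothing available explains either large step.

Open, from the compounds shown here alone, is whether a small group such as methyl or methoxy on this ring would give a similar large step. Going by these compounds, it is also open whether the amino group and the ring fluorine each contribute to the step to compound 2.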